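Solubility after swapping the basic ring on compound 3

The compounds below may be only part of what the source reports. "The series", "measured", "known", "first", "only" and "open" are said of these compounds alone.

Measured so far:
compound 1 `CNc1nccc(N2CC[C@H](NC(=O)Nc3ccc(Cl)c(C(F)(F)F)c3)C2)n1`: 22200 nM
compound 2 `CNc1nccc(N2CC[C@H](NC(=O)Nc3ccc(OC(F)F)cc3)C2)n1`: 92800 nM
compound 3 `CNc1nccc(N2CC[C@H](NC(=O)Nc3ccc(CN4CCN(C)CC4)c(C(F)(F)F)c3)C2)n1`: 67500 nM

These three compounds share one core and differ only in the substituted benzene attached to the urea. In a physicochemical assay for solubility, measured as kinetic solubility (a lower number here means a less soluble compound, a higher number a more soluble compound), compound 3 gives 67500 nM, the second highest of the three numbers; compound 2 sits within the scatter of it, while compound 1 sits beyond the scatter below it, as the step of a 3.0-fold higher number from compound 1 to compound 3 (0.48 log units; beyond the scatter) shows.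

Compound 4 `CNc1nccc(N2CC[C@H](NC(=O)Nc3ccc(CN4CCCC4)c(C(F)(F)F)c3)C2)n1` is not yet measured. It differs from compound 3 in one place: pyrrolidin-1-yl in place of 4-methylpiperazin-1-yl on a saturated chain carbon bound to an aromatic carbon.

For the measured compounds named here, no measured step swaps one saturated ring for another, so nothing bears on this change directly. Going by the values given here, the only step available, a 3.0-fold higher number from compound 1 to compound 3 (0.48 log units; beyond the scatter), says that bringing in the (4-methylpiperazin-1-yl)methyl group in place of chloro raised the number modestly. Compound 4 keeps a ring of that kind, but a smaller one, so a somewhat lower number than compound 3 is expected, of about the size a 1.7-fold lower number from compound 3 to compound 4 (0.23 log units; within the scatter), close to the edge of the scatter. For compound 4 a value of 40000 nM is estimated, within a range from 18000 nM to 90000 nM.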

Compound 4, solubility: 37400 nM
The estimate for compound 4 lay 1.1-fold (0.03 log units) above the measured number; low and high end bracket the measured number.
By their numbers in this assay, from the lowest: compounds 1, 4, 3 and 2 (each within the scatter of the next, the first and the last beyond it).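

In this assay, putting pyrrolidin-1-yl in place of 4-methylpiperazin-1-yl on a saturated chain carbon bound to an aromatic carbon gives a 1.8-fold lower number from compound 3 to compound 4 (0.26 log units; within the scatter), so this first direct comparison of two saturated rings at this place shows no difference that can be told apart from the noise of repeated measurements. The comparison with chloro is less clear-cut: (pyrrolidin-1-yl)methyl gives a 1.7-fold higher number from compound 1 to compound 4 (0.23 log units; within the scatter), whereas (4-methylpiperazin-1-yl)methyl gives a 3.0-fold higher number from compound 1 to compound 3 (0.48 log units; beyond the scatter), so the step away from chloro clears the scatter with one ring and not with the other, even though the two rings themselves cannot be separated. Nothing measured here explains these numbers or connects them to any property of the groups.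

Two rings are too few to show whether ring size or the second ring nitrogen matters, or whether either one matters at all. A morpholin-4-yl or piperidin-1-yl ring on the same carbon, or an open-chain dimethylamino group there, would test whether any change at this place moves the number beyond the scatter.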